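This account rests on a few compounds, and the source may have more. Where it says the series, first, only, none or still open, it means among the compounds named here.

Measured so far:
compound 1, `O=C(/C=C/c1ccc(Br)cc1)Nc1ccc2ncnc(Nc3cccc(Br)c3)c2c1`, which in a functional assay on A549 cells (Homo sapiens) for antiproliferative activity, read by MTT assay, with a stated time of 48 h (on this read-out lower numbers stand for stronger inhibition and higher numbers for weaker inhibition), gives 15.3 ug/mL;
compound 2, `O=C(/C=C/c1ccccc1Cl)Nc1ccc2ncnc(Nc3cccc(Cl)c3)c2c1`, which in this assay gives 4.58 ug/mL.

Compound 2 holds the lower of the two numbers in this assay; compound 1 stands above it by a margin that lies beyond the usual scatter. Among the compounds with values here, the two differ in more than one place, so the two values show only that compound 2 is the more active of the pair. Compound 3, `O=C(/C=C/c1ccc(Br)cc1)Nc1ccc2ncnc(Nc3cccc(Cl)c3)c2c1`, has not yet been measured. It is reached from compound 2 by one change: 4-bromophenyl in place of 2-chlorophenyl on a double-bonded chain carbon bound to a double-bonded chain carbon. Compound 3 thus carries the chain-end group of compound 1 on the shared core of compound 2. Since compound 1 gives 15.3 ug/mL and compound 2 gives 4.58 ug/mL, a modest move toward a higher number in this assay is expected, written as a 1.9-fold higher number from compound 2 to compound 3 (0.27 log units; within the scatter). Compound 3 is therefore estimated at 8.5 ug/mL, within a range from 3.5 ug/mL to 20 ug/mL.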

Compound 3, half-maximal inhibitory concentration: 1.86 ug/mL
The estimate for compound 3 lay 4.6-fold (0.66 log units) above the measured number; measured number outside the range, below it.
By their numbers in this assay, from the lowest: compound 3; then compound 2; then compound 1.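

In this assay, the chain-end group can now be read on its own: 4-bromophenyl in place of 2-chlorophenyl on the double-bonded chain carbon gives a 2.5-fold lower number from compound 2 to compound 3 (0.39 log units; beyond the scatter), so the number at this place answers to the change with the shared core held fixed. The other difference between the first two compounds can also be read: chloro in place of bromo on an aromatic carbon gives an 8.2-fold lower number from compound 1 to compound 3 (0.92 log units; beyond the scatter), which is likewise beyond the usual scatter. No measurement is at hand that would explain either step.

Going by these compounds, whether the first step comes from the halogen itself or from where it sits on the ring stays open, and a 4-chlorophenyl group at the same place would separate the two. On these data alone, how an amine or a carboxylic acid on that ring, or a longer chain, would read in this assay is also open.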